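Piperazine in place of dimethylamine on a pentyl chain

The source may hold more compounds than are shown below. What is called first, only, known or untested is meant among the compounds shown, and "the series" means these compounds.

Measured compounds:
compound 1, `CN(C)CCCCCn1c2c(c3ccccc31)C(=O)c1c[n+]([O-])c3ccccc3c1C2=O`: 470 nM
compound 2, `O=C1c2c[n+]([O-])c3ccccc3c2C(=O)c2c1c1ccccc1n2Cc1cn([C@H]2O[C@H](CO)[C@@H](O)[C@H]2O)nn1`: 710 nM

Of the compounds shown here, two have been tested in a functional assay on HCT-116 cells (Homo sapiens) for cytotoxicity, read by MTT assay, with a stated time of 72 h; on this read-out lower numbers stand for stronger inhibition and higher numbers for weaker inhibition. Compound 1 `CN(C)CCCCCn1c2c(c3ccccc31)C(=O)c1c[n+]([O-])c3ccccc3c1C2=O` gives 470 nM in this assay, and compound 2 `O=C1c2c[n+]([O-])c3ccccc3c2C(=O)c2c1c1ccccc1n2Cc1cn([C@H]2O[C@H](CO)[C@@H](O)[C@H]2O)nn1` gives 710 nM. Compound 1 holds the smaller of the two numbers, but the gap to compound 2 lies within the usual scatter, so the two cannot be told apart on these data.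

Compound 3 `CCCN1CCN(CCCCn2c3c(c4ccccc42)C(=O)c2c[n+]([O-])c4ccccc4c2C3=O)CC1` has not yet been measured. It differs from compound 1 in one place: 4-propylpiperazin-1-yl in place of (dimethylamino)methyl on a saturated chain carbon, four bonds along the chain from an aromatic nitrogen. The shared core is unchanged, and the chain keeps its length to the aromatic nitrogen.

Going by the values given here, no step between measured compounds is available to calibrate this change. The two measured values sit close together, and the change is confined to the end of the chain, so the step of a 1.0-fold lower number from compound 1 to compound 3 (0.02 log units; within the scatter) is expected to stay within the scatter, with no clear direction. On that basis compound 3 is estimated at 450 nM in this assay, within a range of 150 nM to 1400 nM.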

Compound 3, half-maximal inhibitory concentration: 790 nM
Beside the measured number, compound 3's estimate is 1.8-fold (0.24 log units) below it, within the range that was stated.
By their numbers in this assay, from the lowest: compounds 1, 2 and 3 (each within the scatter of the next).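

In this assay, going by these compounds alone, the exchange of (dimethylamino)methyl for 4-propylpiperazin-1-yl, on a saturated chain carbon, four bonds along the chain from an aromatic nitrogen, gives a 1.7-fold higher number from compound 1 to compound 3 (0.23 log units; within the scatter) and thus no step that can be told from the scatter. This position therefore accepts a group of 9 heavy atoms with a six-membered non-aromatic ring in place of one of 4 heavy atoms with no ring, with the chain keeping its length to the aromatic nitrogen and the shared core unchanged. Within the data shown here, compound 1 and compound 3 form the only pair here that differs in one place, and no other data bear on what lies behind this result.

From the compounds shown here alone, it remains open whether the same holds for a morpholine, a piperidine or a piperazine with no propyl group at the end of the chain, since this single step cannot separate the contribution of the ring from that of its propyl group. Going by these compounds, it is equally open how a shorter or longer chain between the aromatic nitrogen and the 4-propylpiperazin-1-yl group would read in this assay.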